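Swapping a trimethoxyphenyl for a fluorophenyl on the benzophenone

The compounds below may be only part of what the source reports. "The series", "measured", "known", "first", "only" and "open" are said of these compounds alone.

Going by the values given here, compound 2 `COc1cc(OC)c(C(=O)c2ccc(OC)c(OC(=O)CCC(=O)OC[C@@H]3C=C[C@H](n4cc(C)c(=O)[nH]c4=O)O3)c2)cc1OC` holds the lowest number of the two compounds measured so far in a functional assay on HeLa cells (Homo sapiens) for antiproliferative activity, read by MTT assay, with a stated time of 48 h; a lower number here means a stronger inhibitor, a higher number a weaker inhibitor; compound 2 gives 2650 nM. Among the compounds with values here, its nearest neighbour is compound 1 `COc1ccc(C(=O)c2cccc(Cl)c2)cc1OC(=O)CCC(=O)OC[C@@H]1C=C[C@H](n2cc(C)c(=O)[nH]c2=O)O1`, which in this assay gives 6510 nM, and the single measured step, a 2.5-fold lower number from compound 1 to compound 2 (0.39 log units; beyond the scatter), came with 2,4,5-trimethoxyphenyl in place of 3-chlorophenyl on a carbonyl carbon. Compound 3 `COc1ccc(C(=O)c2ccc(F)cc2)cc1OC(=O)CCC(=O)OC[C@@H]1C=C[C@H](n2cc(C)c(=O)[nH]c2=O)O1` has not yet been measured; it differs from compound 2 by 4-fluorophenyl in place of 2,4,5-trimethoxyphenyl on a carbonyl carbon. This change runs the earlier step partly back: a halogen-bearing phenyl again replaces the 2,4,5-trimethoxyphenyl. Because compound 1, the other halophenyl compound, gave 6510 nM, a modest rise toward that number is expected, and the step from compound 2 to compound 3 is estimated at a 2.1-fold higher number from compound 2 to compound 3 (0.32 log units; beyond the scatter). Compound 3 is therefore expected to give 5500 nM in this assay, within a range of 2300 nM to 13000 nM.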

Compound 3, half-maximal inhibitory concentration: 17800 nM
Compound 3: the middle estimate sits 3.2-fold (0.51 log units) below what was measured, outside the stated range (above it).
By their numbers in this assay, from the lowest: compound 2; then compound 1; then compound 3.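

In this assay the group on the carbonyl carbon has a wider reach than the first step showed: 4-fluorophenyl in place of 2,4,5-trimethoxyphenyl comes with a 6.7-fold higher number from compound 2 to compound 3 (0.83 log units; beyond the scatter). The two halogen-bearing phenyl groups also differ from each other, with 4-fluorophenyl in place of 3-chlorophenyl bringing a 2.7-fold higher number from compound 1 to compound 3 (0.44 log units; beyond the scatter), so among these compounds the presence of a halogen on this ring does not by itself fix the number. Nothing available here bears on what lies behind these steps.

On these data alone, how a 4-chlorophenyl or a plain phenyl would stand at this place remains open, and that comparison would separate the identity of the halogen from where it sits. As far as these compounds go, it is also open whether all the methoxy groups of the 2,4,5-trimethoxyphenyl are needed for its lower number, or whether a single 4-methoxyphenyl would give a similar value.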